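The compounds below may be only part of what the source reports. "The series", "measured", "known", "first", "only" and "open" are said of these compounds alone.

Compound 1, `COc1cc(CNC(=O)CCCC/C=C/C(C)C)ccc1OCCCCOc1ccc(C(N)=S)cc1`, in a functional assay on HeLa cells (Homo sapiens) for antiproliferative activity, read by MTT assay, with a stated time of 48 h (on this read-out lower numbers stand for stronger inhibition and higher numbers for weaker inhibition), gives > 50000 nM, a limit of the assay and not a number.
Compound 2, `COc1cc(CNC(=O)CCCC/C=C/C(C)C)ccc1OC(=O)CCC(=O)Oc1ccc(-c2cc(=S)ss2)cc1`, in this assay gives 4250 nM.
Compound 3, `COc1cc(CNC(=O)CCCC/C=C/C(C)C)ccc1OC(=O)CCC(=O)Oc1ccc(C(N)=S)cc1`, in this assay gives > 50000 nM, a limit of the assay and not a number.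

The four compounds share an amide-bearing core joined through a linker to a second aromatic ring that carries either a thioamide-type group or a five-membered sulfur ring. Compound 3 and compound 2 differ in one place only: a group of 6 heavy atoms (3 carbon, 3 sulfur; one five-membered aromatic ring with 2 hetero atoms) in place of a group of 3 heavy atoms (1 carbon, 1 nitrogen, 1 sulfur; no ring), on an aromatic carbon. That change gives an at least 11-fold lower number from compound 3 to compound 2 (1.07 log units; beyond the scatter). As compound 3 sits at the limit of > 50000 nM in this assay, at which 2 of the 3 values shown sit, the true size of this step is not known, only its floor.

Compound 1 and compound 3 carry the same group on the second ring but differ in the linker; the difference between the two cores is not broken down here. Both sit at the limit, so their values show no difference between them.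

Compound 4, `COc1cc(CNC(=O)CCCC/C=C/C(C)C)ccc1OCCCCOc1ccc(-c2cc(=S)ss2)cc1`, is not yet measured in this assay. It differs from compound 1 by the same change that turns compound 3 into compound 2: a group of 6 heavy atoms (3 carbon, 3 sulfur; one five-membered aromatic ring with 2 hetero atoms) in place of a group of 3 heavy atoms (1 carbon, 1 nitrogen, 1 sulfur; no ring), on an aromatic carbon. Because compound 1 sits at the limit of > 50000 nM in this assay, at which 2 of the 3 values shown sit, and the measured step is an at least 11-fold lower number from compound 3 to compound 2 (1.07 log units; beyond the scatter), compound 4 is expected to fall clearly below that limit, with an expected step of an at least 8.3-fold lower number from compound 1 to compound 4 (0.92 log units; beyond the scatter). The estimate for compound 4 in this assay is 6000 nM, expected to lie between 2000 nM and 30000 nM.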

Compound 4, half-maximal inhibitory concentration: 47100 nM
Beside the measured number, compound 4's estimate is 7.9-fold (0.89 log units) below it; the measured number lies above the stated range.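

In this assay, the five-membered sulfur ring in place of the thioamide-type group on the core of compound 1 gives an at least 1.0-fold lower number from compound 1 to compound 4 (0.02 log units; that floor lies within the scatter). Set beside the earlier step, the same change gives a floor beyond the scatter on one core and a floor within the scatter on the other, yet these floors do not establish a real difference between the two cores: the same change on two cores in this assay, an at least 11-fold lower number (1.07 log units; beyond the scatter) from compound 3 to compound 2 and an at least 1.0-fold lower number (0.02 log units; that floor lies within the scatter) from compound 1 to compound 4; the limit leaves it open whether they differ. The series therefore shows that the change can be made on both cores without raising the number, but it does not show how large either step truly is, nor whether the size of the change carries over from one core to the other: the limit of > 50000 nM in this assay, at which 2 of the 4 values shown sit.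

The thioamide-type compounds leave open where each one would truly lie, so the effect of the linker on the thioamide-type group cannot be read from them. As far as these compounds go, it also remains open how the two cores would respond if an amine or a carboxylic acid stood in place of these groups on the second ring, or if a longer chain joined the two halves of the molecule.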